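Anilide acrylamides: stability of compound 4 from compound 2

This account rests on a few compounds, and the source may have more. Where it says the series, first, only, none or still open, it means among the compounds named here.

Measured compounds:
- compound 1, `O=C(/C=C/CC(=O)Nc1ccccc1)Nc1ccccc1`: > 8.53 h
- compound 2, `C=C(CO)C(=O)Nc1ccccc1`: > 8.53 h
- compound 3, `O=C(/C=C/C(F)(F)F)Nc1ccccc1`: 0.267 h

All three share the anilide core. In an ADME assay for pharmacokinetics, read by LC-MS, in phosphate buffer, with a stated time of 120 min, at pH 7.4, tested at 1 uM, in the presence of a further agent that is not named here (a higher number here means that the compound lasts longer, a lower number that the compound disappears faster), compound 1 reaches only a limit of the assay, > 8.53 h. Compound 2 likewise gives a limit in this assay, > 8.53 h, and no number within the measured range. Among the measured compounds shown here, compound 3 is the one compound with a numerical half-life, 0.267 h. That number falls well short of where compound 1 and compound 2 sit (the limit of > 8.53 h in this assay, at which 2 of the 3 values shown sit). Compound 2 therefore stands at the long-lived end of what is shown, together with compound 1, and no step between measured compounds is available to calibrate a change on the chain.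

The next compound, compound 4, is `C=C(C)C(=O)Nc1ccccc1`. It differs from compound 2 by hydrogen in place of hydroxy on a saturated chain carbon bound to a double-bonded chain carbon. For the measured compounds named here, with no measured step for this kind of change, the working expectation is that the half-life of compound 4 stays near the limit, with a step from compound 2 of a number no higher from compound 2 to compound 4 (the limit leaves the size open), that is, none beyond the scatter in either direction. The estimate for compound 4 in this assay is 8.5 h, with a range of 2.5 h to 25 h, and a fair chance that only a limit is again reported.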

Compound 4, half-life: > 8.53 h
Compound 4 gave a limit, no number (the forecaster's own chance of this, stated with the estimate: 60%); middle value at least 1.0-fold (0.00 log units) away from the limit.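

Compound 2 and compound 4 both stand at a limit of this assay, so no step can be read between them: the limit of > 8.53 h in this assay, at which 3 of the 4 values shown sit.

The compounds shown leave open whether hydrogen in place of hydroxy on a saturated chain carbon bound to a double-bonded chain carbon changes the half-life at all.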